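Aryl group on the triazole nitrogen in a urea series

This account rests on a few compounds, and the source may have more. Where it says the series, first, only, none or still open, it means among the compounds named here.

Measured compounds:
compound 1 `Cc1ccc(-n2cc(COc3cccc(NC(=O)Nc4ccc(Cl)c(C(F)(F)F)c4)c3)nn2)cc1` — 5430 nM
compound 2 `N#Cc1ccc(-n2cc(COc3cccc(NC(=O)Nc4ccc(Cl)c(C(F)(F)F)c4)c3)nn2)cc1` — 2980 nM
compound 3 `CC(C)c1cccc(-n2cc(COc3cccc(NC(=O)Nc4ccc(Cl)c(C(F)(F)F)c4)c3)nn2)c1` — 3250 nM

In a functional assay on HepG2 cells (Homo sapiens) for inhibition, read by MTT assay, with a stated time of 72 h (on this read-out lower numbers stand for stronger inhibition and higher numbers for weaker inhibition), compound 1 gives the highest number of the three shown, yet its separation from the other two stays within the scatter: a 1.8-fold lower number from compound 1 to compound 2 (0.26 log units; within the scatter) and a 1.7-fold lower number from compound 1 to compound 3 (0.22 log units; within the scatter). Compound 2 and compound 3 likewise sit together, a 1.1-fold higher number from compound 2 to compound 3 (0.04 log units; within the scatter). The shared core is held constant across all three; only the aryl group on the aromatic nitrogen of the five-membered ring varies.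

Compound 4 `O=C(Nc1cccc(OCc2cn(-c3ccccc3C(F)(F)F)nn2)c1)Nc1ccc(Cl)c(C(F)(F)F)c1` continues this variation: 2-(trifluoromethyl)phenyl in place of 4-methylphenyl on an aromatic nitrogen.

Going by the values given here, the steps that bear on it are those from compound 1 to compound 2 and from compound 1 to compound 3, both of which exchange the aryl group at the same place and both of which stay within the scatter. Among the compounds with values here, nothing measured so far suggests that an exchange here moves this read-out beyond the scatter. The expectation for compound 4 is therefore a step of no real size, a 1.4-fold lower number from compound 1 to compound 4 (0.13 log units; within the scatter), with the estimate for compound 4 put at 4000 nM and expected to fall between 1600 nM and 10000 nM.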

Compound 4, half-maximal inhibitory concentration: 2320 nM
The estimate for compound 4 lay 1.7-fold (0.24 log units) above the measured number; low and high end bracket the measured number.
By their numbers in this assay, from the lowest: compounds 4, 2, 3 and 1 (each within the scatter of the next, the first and the last beyond it).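

In this assay, the aryl group on the aromatic nitrogen gives its first step beyond the scatter, though a modest one, when 2-(trifluoromethyl)phenyl enters for 4-methylphenyl (a 2.3-fold lower number from compound 1 to compound 4 (0.37 log units; beyond the scatter)). That separation holds only against compound 1, since compound 4 stays within the scatter of the other two aryl variants (a 1.4-fold lower number from compound 3 to compound 4 (0.15 log units; within the scatter); a 1.3-fold lower number from compound 2 to compound 4 (0.11 log units; within the scatter)). Nothing available accounts for the separation from compound 1.

The 2-(trifluoromethyl)phenyl group differs from 4-methylphenyl in both its substituent and that substituent's place on the phenyl ring, and the compounds shown do not separate these two changes. From the compounds shown here alone, it also remains open how this read-out responds to an aryl group carrying an amine or a carboxylic acid, or to a longer alkyl chain on the same nitrogen.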